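Swapping the Aryl Group on an Aromatic Nitrogen

This account rests on a few compounds, and the source may have more. Where it says the series, first, only, none or still open, it means among the compounds named here.

Three compounds share a large fused core that carries a nitrile, an amine and a lactam, with a five-membered aromatic ring of three nitrogens bearing an aryl group. Compound 1 `N#CC1=C(N)Oc2c(c3nc4ccccc4nc3c3ccccc23)C12C(=O)N(Cc1cnnn1-c1ccc(S(N)(=O)=O)cc1)c1ccccc12`, tested in a functional assay on HCT-116 cells (Homo sapiens) for antiproliferative activity, read by MTT assay, with a stated time of 48 h (on this read-out lower numbers stand for stronger inhibition and higher numbers for weaker inhibition), gives 31200 nM. Compound 2 `Cc1ccc(C)c(-n2nncc2CN2C(=O)C3(C(C#N)=C(N)Oc4c3c3nc5ccccc5nc3c3ccccc43)c3ccccc32)c1` gives only a limit of the assay, > 50000 nM, in this assay. That change is an at least 1.6-fold higher number from compound 1 to compound 2 (0.20 log units; that floor lies within the scatter). Compound 3 `CC(=O)Nc1ccc(-n2nncc2CN2C(=O)C3(C(C#N)=C(N)Oc4c(N)cc5nc6ccccc6nc5c43)c3ccccc32)cc1`, whose core additionally carries an amino group, also gives only a limit, > 50000 nM, in this assay. Compound 3 therefore sits at the limit of > 50000 nM in this assay, at which 2 of the 3 values shown sit.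

Compound 4 `N#CC1=C(N)Oc2c(N)cc3nc4ccccc4nc3c2C12C(=O)N(Cc1cnnn1-c1ccc(Cl)cc1Cl)c1ccccc12` keeps the core of compound 3 and alters the aryl group: 2,4-dichlorophenyl in place of 4-acetamidophenyl on an aromatic nitrogen. Among the compounds with values here, no measured step exchanges exactly these two groups. The nearest comparison is the step from compound 1 to compound 2, which also exchanged the aryl group on that nitrogen and ended at the limit, though the measured floor lies within the scatter. Compound 4 is thus expected to remain at or near the limit in this assay, with an estimated 55000 nM and a range from 20000 nM to 150000 nM. This corresponds to an expected step that the limit leaves unreadable from compound 3 to compound 4.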

Compound 4, half-maximal inhibitory concentration: > 50000 nM
Compound 4: no number, only a limit (the forecaster's own chance of this, stated with the estimate: 65%); the middle value does not contradict the limit.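

In this assay compound 4 gives only a limit, > 50000 nM. Within the data shown here, compound 3 also gives only a limit, so no step between compound 3 and compound 4 can be read: the limit of > 50000 nM in this assay, at which 3 of the 4 values shown sit. Going by these compounds, whether 2,4-dichlorophenyl and 4-acetamidophenyl differ at all on this core stays open, since neither compound has a number.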